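The source may hold more compounds than are shown below. What is called first, only, known or untested is meant among the compounds shown, and "the series" means these compounds.

Working notes on the series in a functional assay on CCRF-CEM cells (Homo sapiens), read by MTT assay, with a stated time of 72 h; a lower number here means a stronger inhibitor, a higher number a weaker inhibitor. Compound 3 `C#Cc1cn([C@@H]2O[C@H](CO)[C@@H](O)[C@H]2O)c2ncnc(NC)c12` carries ethynyl on the shared core and gives > 20000 nM, which is a limit and not a number. Compound 1 `CNc1ncnc2c1c(-c1cccs1)cn2[C@@H]1O[C@H](CO)[C@@H](O)[C@H]1O`, with thiophen-2-yl, gives > 20000 nM, also a limit. Compound 2 `CNc1ncnc2c1c(-c1cc3ccccc3o1)cn2[C@@H]1O[C@H](CO)[C@@H](O)[C@H]1O`, with 1-benzofuran-2-yl, gives > 20000 nM, again a limit. All three therefore sit together: the limit of > 20000 nM in this assay, at which 3 of the 3 values shown sit.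

Compound 4 `C#Cc1cn([C@@H]2O[C@H](CO)[C@@H](O)[C@H]2O)c2ncnc(N(C)C)c12` differs from compound 3 by methyl in place of hydrogen on a nitrogen on an aromatic ring, so methylamino becomes dimethylamino.

The measured steps bear on this only loosely: a step that the two limits leave unreadable from compound 1 to compound 2, a step that the two limits leave unreadable from compound 1 to compound 3 and a step that the two limits leave unreadable from compound 2 to compound 3. None has a readable size, and each changes the group on an aromatic carbon rather than the group on the nitrogen. Going by the values given here, no measured compound yet shows what the added methyl does. In this assay, no step beyond the scatter is expected, and no direction can be assigned. This expectation rests on compound 3 at > 20000 nM, which remains a limit. The estimated step is a number no higher from compound 3 to compound 4 (the limit leaves the size open). The expected value for compound 4 is 20000 nM, with an estimated range of 10000 nM to 40000 nM, and a report as a limit is the likeliest outcome.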

Compound 4, half-maximal inhibitory concentration: 90 nM
Estimate against measurement, compound 4: 220-fold (2.35 log units) above; the whole stated range lies above it.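

In this assay, the group on the nitrogen carries a large effect in the ethynyl compounds: going from methylamino to dimethylamino gives an at least 220-fold lower number from compound 3 to compound 4 (2.34 log units; beyond the scatter). The earlier steps shown here all changed the group on an aromatic carbon while methylamino stayed in place, and none of them can be read, leaving the series without any measured size of change until now. Going by these compounds alone, this is the first readable step, it comes from one added methyl on a nitrogen on an aromatic ring, and it sets a single measured number against a background of limits: the limit of > 20000 nM in this assay, at which 3 of the 4 values shown sit.

On these data alone, it remains open whether dimethylamino has the same effect with thiophen-2-yl or 1-benzofuran-2-yl on the aromatic carbon in place of ethynyl, and therefore whether the step depends on the ethynyl group. The compounds shown also do not tell whether methyl is special on this nitrogen, since an unsubstituted amino group, ethylamino, diethylamino or a pyrrolidin-1-yl group at the same place would be needed to show how far the trend extends.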